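Fluoro Added to the Phenyl Group of Compound 3

This account rests on a few compounds, and the source may have more. Where it says the series, first, only, none or still open, it means among the compounds named here.

Compound 3 `C#CC(=O)N1C(c2ccccc2)SC[C@@H]1C(=O)OCC` gives 400 nM in a functional assay on MV cells (Homo sapiens) for inhibition, read by sulforhodamine B assay (on this read-out higher numbers stand for weaker inhibition and lower numbers for stronger inhibition), the smallest number among the three measured compounds. Compound 2 `C#CC(=O)N1C(C(C)CCC)SC[C@@H]1C(=O)OCC` gives 500 nM, and the step of a 1.3-fold lower number from compound 2 to compound 3 (0.10 log units; within the scatter) lies within the scatter. Compound 1 `C#CC(=O)N1C(C(CC)CCCC)SC[C@@H]1C(=O)OCC` gives 1600 nM, so that a 4.0-fold lower number from compound 1 to compound 3 (0.60 log units; beyond the scatter) and a 3.2-fold lower number from compound 1 to compound 2 (0.51 log units; beyond the scatter) are modest steps. Compound 4 `C#CC(=O)N1C(c2ccccc2F)SC[C@@H]1C(=O)OCC` differs from compound 3 by fluoro in place of hydrogen on an aromatic carbon. All measured steps concern the group on the saturated ring carbon, and none alters the phenyl group itself, so they offer no direct guide to this change. For compound 4 the expected step of no change at the digits printed from compound 3 to compound 4 (within the scatter) is therefore none beyond the scatter. Compound 4 is estimated at 400 nM, with a range from 200 nM to 800 nM.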

Compound 4, half-maximal inhibitory concentration: 1700 nM
Compound 4: middle estimate off by 4.3-fold (0.63 log units), on the low side; measured number above the stated range.
By their numbers in this assay, from the lowest: compounds 3 and 2 (each within the scatter of the next); then compounds 1 and 4 (each within the scatter of the next).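

In this assay the phenyl group of compound 3 proves sensitive to a single added atom: fluoro in place of hydrogen, ortho to a large group, gives a 4.3-fold higher number from compound 3 to compound 4 (0.63 log units; beyond the scatter) and so a modest step beyond the scatter. The 2-fluorophenyl group also stands apart from 1-methylbutyl with a 3.4-fold higher number from compound 2 to compound 4 (0.53 log units; beyond the scatter) but cannot be told from 1-ethylpentyl with a 1.1-fold higher number from compound 1 to compound 4 (0.03 log units; within the scatter) within the scatter. Nothing available accounts for this step. As far as these compounds go, whether chloro or methoxy on the same aromatic carbon would behave like fluoro stays open, as does the effect of fluoro on another carbon of the ring.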